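Amide swap in the benzoxazole-free core: pyrrolidine to hydroxypiperidine

A few compounds are considered here, and "the series" means these few. Any claim that something is new, unique, unknown or untested is made for them only; others in the source may bear on it.

Measured compounds in an assay on isolated protein for inhibition of thyroid hormone receptor beta (Homo sapiens), read by fluorescence, with a stated time of 30 min; on this read-out lower numbers stand for stronger inhibition and higher numbers for weaker inhibition:
- compound 1 `O=C(NCc1cccc(Cl)c1)c1ccc2cn(CCN3CCOC3=O)nc2c1` gives 220 nM
- compound 2 `COc1cc(C(=O)N2CCCC2)cc2nc(NCc3cccc(Cl)c3)oc12` gives 180 nM

Compound 2 has the lowest of the two numbers in this assay; compound 1 sits within the scatter of it, so no order between them is claimed. Compound 3 `COc1cc(C(=O)N2CCC(O)CC2)cc2nc(NCc3cccc(Cl)c3)oc12` differs from compound 2 by 4-hydroxypiperidin-1-yl in place of pyrrolidin-1-yl on a carbonyl carbon. Within the data shown here, no step between measured compounds is available to calibrate this change. The step of a 1.4-fold higher number from compound 2 to compound 3 (0.14 log units; within the scatter) is expected to stay within the scatter, leaning toward a slightly higher number. Compound 3 is expected at 250 nM, with a range of 90 nM to 700 nM.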

Compound 3, half-maximal inhibitory concentration: 352 nM
Estimate against measurement, compound 3: 1.4-fold (0.15 log units) below; the measured number falls inside the stated range.
By their numbers in this assay, from the lowest: compounds 2, 1 and 3 (each within the scatter of the next).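

In this assay the carbonyl position takes 4-hydroxypiperidin-1-yl in place of pyrrolidin-1-yl with a 2.0-fold higher number from compound 2 to compound 3 (0.29 log units; within the scatter) and so gives no order between the two amides. At this position, then, a six-membered ring carrying a hydrogen-bond donor and acceptor is not separated from the five-membered ring that carries neither. Nothing on hand bears on the reason for this step.

The ring size and the hydroxy group remain unseparated here, and unsubstituted piperidin-1-yl on the same carbonyl would address that. Morpholin-4-yl or an open-chain dimethylamino group at this position also remains open.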